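The source may hold more compounds than are shown below. What is called first, only, known or untested is meant among the compounds shown, and "the series" means these compounds.

Compound 1 `FC(F)(F)Cc1cnc2c(Cl)c(-c3cc(Cl)c4c(ccn4CC4CC4)c3)ccn12` gives 250 nM in a functional assay on CHO cells for agonist activity at metabotropic glutamate receptor 2 (Homo sapiens), read by GTPgammaS binding; a higher number here means that more compound is needed for the effect, a lower number that less compound is needed.
Compound 2 `N#Cc1c(-c2ccc(NC3CCOCC3)c(Cl)c2)ccn2c(CC(F)(F)F)cnc12` gives 710 nM in this assay.
Compound 3 `Cn1ccc2cc(-c3ccn4c(CC(F)(F)F)cnc4c3C#N)cc(Cl)c21` gives 120 nM in this assay.

Among these three, compound 3 stands at the lowest number in this assay. The nearest to it is compound 1, whose number is higher by a margin beyond the usual scatter; compound 2 lies further off still, also beyond the scatter. Compound 1 and compound 2 each differ from compound 3 in more than one place, so none of these gaps isolates a single change.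

For the measured compounds named here, compound 4 `N#Cc1c(-c2cc(Cl)c3[nH]ccc3c2)ccn2c(CC(F)(F)F)cnc12` is the one compound not yet measured. It differs from compound 3 in one place: hydrogen in place of methyl on an aromatic nitrogen. Going by the values given here, no pair of measured compounds shows this change on its own, so the size of the step cannot be read from the data. The author expects a small step upward in number, from compound 3 to compound 4, that may not clearly exceed the scatter, a 2.5-fold higher number from compound 3 to compound 4 (0.40 log units; beyond the scatter). Compound 4 is therefore estimated at 300 nM, with a likely range from 100 nM to 1000 nM.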

Compound 4, half-maximal effective concentration: 320 nM
Compound 4: the middle estimate sits 1.1-fold (0.03 log units) below what was measured; measured number inside the range.
By their numbers in this assay, from the lowest: compound 3; then compounds 1 and 4 (each within the scatter of the next); then compound 2.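

In this assay, for the compounds shown here, hydrogen in place of methyl on an aromatic nitrogen gives a 2.7-fold higher number from compound 3 to compound 4 (0.43 log units; beyond the scatter), and this is the first step in the set that isolates a single change. It shows that the methyl at this position is not needed for a measurable effect, although compound 3, which carries it, has the lower number of the pair and the step is modest. Nothing at hand bears on why the number moves in this direction.

Compound 1 carries a cyclopropylmethyl group on the same kind of nitrogen but also differs from compound 3 elsewhere, so it cannot show how a group larger than methyl behaves at this position. On these data alone, how the number would respond to an ethyl group, a longer alkyl chain or an acetyl group on this nitrogen remains open.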